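Pendant aryl ring: methyl removed to give phenyl

The compounds below may be only part of what the source reports. "The series", "measured", "known", "first", "only" and "open" are said of these compounds alone.

Compound 1 `Cc1cnc(Nc2ccc(C(=O)Nc3c(C)cccc3C)cc2)nc1-c1ccc(OC(F)(F)F)c(F)c1`: 159 nM
Compound 2 `Cc1cnc(Nc2ccc(C(=O)Nc3c(C)cccc3C)cc2)nc1-c1ccc(F)cc1`: 2.2 nM
Compound 3 `Cc1ccc(-c2nc(Nc3ccc(C(=O)Nc4c(C)cccc4C)cc3)ncc2C)cc1`: > 500 nM

In an assay on NIH3T3 cells for inhibition of Sonic hedgehog protein (Mus musculus), read by a luciferase reporter, with a stated time of 48 h (a lower number here means a stronger inhibitor, a higher number a weaker inhibitor), compound 1 gives 159 nM and compound 2 gives 2.2 nM, a step of a 72-fold lower number from compound 1 to compound 2 (1.86 log units; beyond the scatter). For compound 3 the assay reports only a limit, > 500 nM. The steps into compound 3 read an at least 3.1-fold higher number from compound 1 to compound 3 (0.49 log units; beyond the scatter) and an at least 220-fold higher number from compound 2 to compound 3 (2.35 log units; beyond the scatter), so compound 3 stands at the weak end of the three, at the limit (the limit of > 500 nM in this assay, at which 1 of the 3 values shown sits).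

Compound 4 `Cc1cnc(Nc2ccc(C(=O)Nc3c(C)cccc3C)cc2)nc1-c1ccccc1` differs from compound 3 by hydrogen in place of methyl on an aromatic carbon. The step of an at least 220-fold higher number from compound 2 to compound 3 (2.35 log units; beyond the scatter) shows that the methyl on this ring goes with a much higher number than fluoro, and an at least 3.1-fold higher number from compound 1 to compound 3 (0.49 log units; beyond the scatter) points the same way. Among the measured compounds shown here, removing the methyl is therefore expected to lower the number, a step of an at least 12-fold lower number from compound 3 to compound 4 (1.09 log units; beyond the scatter) in this assay, though no measured pair shows hydrogen there. Compound 4 is estimated at 40 nM, between 4 nM and 500 nM.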

Compound 4, half-maximal inhibitory concentration: 1.3 nM
The estimate for compound 4 lay 31-fold (1.49 log units) above the measured number, and the stated range ends above it.
By their numbers in this assay, from the lowest: compounds 4 and 2 (each within the scatter of the next); then compound 1. At a limit, above all of these: compound 3.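

In this assay, hydrogen and fluoro on this aromatic carbon cannot be told apart, with a 1.7-fold lower number from compound 2 to compound 4 (0.23 log units; within the scatter), so this position needs no substituent and the weak reading goes with the methyl, with an at least 380-fold lower number from compound 3 to compound 4 (2.58 log units; beyond the scatter). The bare phenyl also stands well clear of the larger 3-fluoro-4-(trifluoromethoxy)phenyl, with a 120-fold lower number from compound 1 to compound 4 (2.09 log units; beyond the scatter). The value of compound 3 is a limit: the limit of > 500 nM in this assay, at which 1 of the 4 values shown sits.

From the compounds shown here alone, whether chloro, methoxy or hydroxyl at this place would read like fluoro or like methyl remains open. Going by these compounds, the true size of the methyl step also remains open.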